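Halogen swap on the aryl group of the shared core

The compounds below may be only part of what the source reports. "The series", "measured", "known", "first", "only" and "open" are said of these compounds alone.

Measured so far in a functional assay on the whole organism (strain Wistar) for inhibition, with Rattus norvegicus as the target, read by paw edema, with stated times of 30 min and 3 h, at a dose of 50 mg/kg by the oral route; a higher number here means more inhibition at the dose given (going by the name of the read-out), a lower number less inhibition:
compound 1 `Cc1ccc(-c2cc3nc(-c4ccc(F)cc4)cc(N)n3n2)cc1`, 26.8%
compound 2 `Nc1cc(-c2ccc(Cl)cc2)nc2cc(-c3ccccc3)nn12`, 28%
compound 3 `Cc1ccc(-c2cc3nc(-c4ccc(Br)cc4)cc(N)n3n2)cc1`, 56.1%

Compound 3 stands highest of the three in this assay, its step to each of the other two beyond the scatter. Compound 4 `Cc1ccc(-c2cc3nc(-c4ccc(Cl)cc4)cc(N)n3n2)cc1` differs from compound 3 by one change: chloro in place of bromo on an aromatic carbon. Among the compounds with values here, one measured step bears on it, a number 29.3 percentage points higher from compound 1 to compound 3 (beyond the scatter), where the halogen on the same aromatic carbon moved from fluoro to bromo and the number rose. Chloro sits between those two halogens, so a step downward from compound 3 is expected, smaller than that one. Within the data shown here, compound 2 carries chloro on a different frame and gives a lower number, but no single-change step connects it to compound 3 or compound 4. For compound 4 the expected step is a number 14.1 percentage points lower from compound 3 to compound 4 (beyond the scatter), giving an estimate of 42%, within 25% to 58%.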

Compound 4, a percentage reported as inhibition, in the whole organism at one dose (the size of the read-out at that dose, not a potency): 64.6%
Compound 4: the middle estimate sits 22.6 percentage points below what was measured; the measured number lies above the stated range.
By their numbers in this assay, from the lowest: compounds 1 and 2 (each within the scatter of the next); then compounds 3 and 4 (each within the scatter of the next).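

In this assay the 4-bromophenyl to 4-chlorophenyl swap gives a number 8.5 percentage points higher from compound 3 to compound 4 (within the scatter), so chloro and bromo at this place are not separated, while fluoro stands apart, with a number 37.8 percentage points higher from compound 1 to compound 4 (beyond the scatter). A second place now reads as well: with chloro held fixed, methyl in place of hydrogen on an aromatic carbon gives a number 36.6 percentage points higher from compound 2 to compound 4 (beyond the scatter). No measurement on hand accounts for either step.

From the compounds shown here alone, whether a methoxy or an amine at the halogen place would read with chloro and bromo or with fluoro stays open. Also open, going by these compounds, is whether the methyl step holds with bromo or fluoro on the other aryl group.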